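Swapping the Amide Side Chain toward the Potent Analogues

A few compounds are considered here, and "the series" means these few. Any claim that something is new, unique, unknown or untested is made for them only; others in the source may bear on it.

Compound 1 `CC(C)C[C@H](N)c1cc(C(F)(F)F)ccc1N1CCN(C(=O)COc2ccc(Cl)cc2)CC1`: 2900 nM
Compound 2 `COc1cc(Cl)ccc1CC(C)C(=O)N1CCN(c2ccc(Cl)cc2[C@@H](N)CC(C)C)CC1`: 9.1 nM
Compound 3 `CC(C)C[C@H](N)c1ccccc1N1CCN(C(=O)[C@H](C)Cc2ccc(Cl)cc2Cl)CC1`: 16 nM

In an assay on HEK293 cells for displacement of a labelled ligand from Melanocortin receptor 4 (Homo sapiens) (a higher number here means a weaker inhibitor, a lower number a stronger inhibitor), compound 1 gives 2900 nM, the highest of the three numbers. Compound 3 gives 16 nM and compound 2 gives 9.1 nM, both far lower and beyond the scatter. Compound 4 `Cc1cc(Cl)ccc1CC(C)C(=O)N1CCN(c2ccc(C(F)(F)F)cc2[C@@H](N)CC(C)C)CC1` has not yet been measured in this assay. It differs from compound 1 in one place: 1-(4-chloro-2-methylbenzyl)ethyl in place of (4-chlorophenoxy)methyl on a carbonyl carbon. The incoming group resembles the side chains of compound 2 and compound 3, which carry the two low numbers. A large fall is therefore expected in this assay, since compound 2 gives 9.1 nM with a closely related chain. The expected step from compound 1 to compound 4 is a 97-fold lower number from compound 1 to compound 4 (1.99 log units; beyond the scatter). Compound 4 is estimated at 30 nM, within 8 nM to 120 nM.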

Compound 4, inhibition constant: 38 nM
For compound 4 the middle estimate is 1.3-fold (0.10 log units) below the measured one; the measured number falls inside the stated range.
By their numbers in this assay, from the lowest: compounds 2 and 3 (each within the scatter of the next); then compound 4; then compound 1.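

In this assay, 1-(4-chloro-2-methylbenzyl)ethyl in place of (4-chlorophenoxy)methyl on a carbonyl carbon gives a 76-fold lower number from compound 1 to compound 4 (1.88 log units; beyond the scatter). Among these compounds, this is the first step that can be read at this position, and it shows that a change in this one group, with the rest of compound 1 kept, is enough for a large fall. Nothing measured here bears on why the number falls. The compounds shown leave open which part of the change carries the step: the lost oxygen, the added methyl or the branch. They also leave open how an amine or a carboxylic acid on this chain would read.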